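The source may hold more compounds than are shown below. What is called first, only, known or untested is meant among the compounds shown, and "the series" means these compounds.

Of the compounds shown here, three have been tested so far in a functional assay on HOS cells (Homo sapiens) for antiproliferative activity, with a stated time of 72 h (a lower number here means a stronger inhibitor, a higher number a weaker inhibitor), and they differ only in one group on an aromatic carbon. Compound 1 (`OC[C@H]1O[C@@H](n2cnc3c(NCc4ccccc4F)ncnc32)[C@H](O)[C@@H]1O`) carries fluoro there and gives > 166000 nM, which is a limit and not a number. Compound 2 (`OC[C@H]1O[C@@H](n2cnc3c(NCc4ccccc4Cl)ncnc32)[C@H](O)[C@@H]1O`) carries chloro and gives > 166000 nM, again a limit. Compound 3 (`COc1ccccc1CNc1ncnc2c1ncn2[C@@H]1O[C@H](CO)[C@@H](O)[C@H]1O`) carries methoxy and gives > 166000 nM, also a limit.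

Compound 4 (`OC[C@H]1O[C@@H](n2cnc3c(NCc4ccccc4OC(F)(F)F)ncnc32)[C@H](O)[C@@H]1O`) has not yet been measured. It differs from compound 3 by trifluoromethyl in place of methyl on an oxygen on an aromatic ring, that is, methoxy to trifluoromethoxy.

The measured steps that bear on this change each exchange one such group for another: a step that the two limits leave unreadable from compound 1 to compound 2, a step that the two limits leave unreadable from compound 1 to compound 3 and a step that the two limits leave unreadable from compound 2 to compound 3. None has a readable size, so they show no trend. Compound 3 offers no sign of activity in this assay because of the limit of > 166000 nM in this assay, at which 3 of the 3 values shown sit, and the same holds for the other two compounds. The new group is therefore expected to bring no change beyond the usual scatter, and a further limit is the most likely report. The expected step is a number no higher from compound 3 to compound 4 (the limit leaves the size open). Compound 4 is expected at about 166000 nM, with an estimated range from 90000 nM to 200000 nM.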

Compound 4, half-maximal inhibitory concentration: > 166000 nM
Compound 4 was reported as a limit; the forecaster's own chance of this, stated with the estimate: 85%; the middle value lies on the limit itself.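

In this assay, within the data shown here, compound 4 gives > 166000 nM, which is a limit and not a number, so no step between compound 4 and compound 1, compound 2 or compound 3 can be read. The compounds shown leave open whether any group at this place can give a readable value, as all of them share one result: the limit of > 166000 nM in this assay, at which 4 of the 4 values shown sit.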